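A few compounds are considered here, and "the series" means these few. Any claim that something is new, unique, unknown or untested is made for them only; others in the source may bear on it.

Compound 3 `COc1ccc(-c2cs/c(=N/NC(=O)CSc3nnc(C)s3)n2-c2ccccc2)cc1` carries a methoxy on the six-membered aromatic ring of carbon only. For the measured compounds named here, in an ADME assay on NIH3T3 cells (Mus musculus) for cytotoxicity, read by MTT assay, with a stated time of 24 h (on this read-out higher numbers stand for weaker inhibition and lower numbers for stronger inhibition), compound 3 gives 300 ug/mL, the second highest of the three numbers so far. Going by the values given here, its nearest neighbour is compound 1 `Cc1nnc(SCC(=O)N/N=c2/scc(-c3ccc(F)cc3)n2-c2ccccc2)s1`, which in this assay gives 383 ug/mL; the only single-point step among the measured compounds, a 1.3-fold lower number from compound 1 to compound 3 (0.11 log units; within the scatter), is fluoro to methoxy on the aromatic carbon. Compound 2 `Cn1nnnc1SCC(=O)N/N=c1/scc(-c2ccc(C#N)cc2)n1-c1ccccc1` gives 213 ug/mL; it differs from compound 3 in two places, so only the two numbers can be set side by side, and they lie within the scatter of each other.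

Compound 4 `Cc1nnc(SCC(=O)N/N=c2/scc(-c3ccc(C#N)cc3)n2-c2ccccc2)s1` differs from compound 3 by cyano in place of methoxy on an aromatic carbon. Among the compounds with values here, the one measured step at this position was within the scatter, and compound 2, which carries the same cyano group on another core, gives a number within the scatter of compound 3. The expected step is therefore a 1.2-fold lower number from compound 3 to compound 4 (0.08 log units; within the scatter), nothing beyond the scatter. Compound 4 is estimated at 250 ug/mL, with a range from 125 ug/mL to 500 ug/mL.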

Compound 4, half-maximal inhibitory concentration: < 3.9 ug/mL
Compound 4 gave a limit, no number (the forecaster's own chance of this, stated with the estimate: 5%); at least 64-fold (1.80 log units) between middle value and limit.
By their numbers in this assay, from the lowest: compounds 2, 3 and 1 (each within the scatter of the next). At a limit, below all of these: compound 4.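

Compound 4 stands at a limit of the assay and not at a number: the limit of < 3.9 ug/mL in this assay, at which 1 of the 4 values shown sits. At the aromatic carbon para to a large group, fluoro and methoxy gave a 1.3-fold lower number from compound 1 to compound 3 (0.11 log units; within the scatter), whereas cyano gives an at least 76-fold lower number from compound 3 to compound 4 (1.88 log units; beyond the scatter) and an at least 98-fold lower number from compound 1 to compound 4 (1.99 log units; beyond the scatter), so this position is not indifferent to the group it carries. The cyano group alone does not give this result, as 5-methyl-1,3,4-thiadiazol-2-yl in place of 1-methyl-1H-tetrazol-5-yl on the sulfur, with cyano kept, gives an at least 54-fold lower number from compound 2 to compound 4 (1.73 log units; beyond the scatter), so among the compounds shown only the pairing of these two groups reaches the limit.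

On these data alone, whether an amine or a carboxylic acid on this aromatic carbon would also give so low a reading remains open. As far as these compounds go, the full size of each step also stays open, as compound 4 has no number.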